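Exchanging the Phenyl Substituent on the Ring Amine

The source may hold more compounds than are shown below. What is called first, only, known or untested is meant among the compounds shown, and "the series" means these compounds.

Measured compounds:
compound 1 `CCCc1nc(-c2ccccc2)c(CNCCN2CCN(c3ccccc3F)CC2)o1` with 46.5%
compound 2 `CCCc1nc(-c2ccccc2)c(CNCCN2CCN(c3ccc(OC)cc3)CC2)o1` with 51.5%

Of the compounds shown here, two sharing one core have been tested in an assay on HEK293 cells for inhibition of Voltage-dependent T-type calcium channel subunit alpha-1G (Homo sapiens), read by fluorescence, tested at 10 uM; a lower number here means less inhibition, a higher number more inhibition at the concentration tested (going by the name of the read-out). In that setting compound 1 gives 46.5%, and compound 2 gives 51.5%. Going by the values given here, compound 2 carries the higher of the two figures, but the only step that links them, a number 5 percentage points higher from compound 1 to compound 2 (within the scatter), lies within the scatter, so the two cannot be told apart on these numbers.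

Compound 3 `CCCc1nc(-c2ccccc2)c(CNCCN2CCN(c3cccc(Cl)c3)CC2)o1` is not yet measured. It differs from compound 2 in one place: 3-chlorophenyl in place of 4-methoxyphenyl on an amine nitrogen in a ring.

Among the compounds with values here, the one measured step that speaks to this change is the earlier exchange of the phenyl substituent on the same ring nitrogen, a number 5 percentage points higher from compound 1 to compound 2 (within the scatter), which did not move the number beyond the scatter. Another exchange of the same kind is therefore expected to leave the read-out where it is, with a number 3.5 percentage points lower from compound 2 to compound 3 (within the scatter) being no more than a movement within the scatter. Compound 3 is expected to give about 48%, within a range from 33% to 63%.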

Compound 3, a percentage reported as inhibition, at one concentration (the size of the read-out at that concentration, not a potency): 51.2%
The estimate for compound 3 lay 3.2 percentage points below the measured number, within the range that was stated.
By their numbers in this assay, from the lowest: compounds 1, 3 and 2 (each within the scatter of the next).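

Swapping the phenyl substituent on the ring nitrogen a second time, now to 3-chlorophenyl, again leaves this assay within the scatter, with a number 0.3 percentage points lower from compound 2 to compound 3 (within the scatter) and, when 3-chlorophenyl takes the place of 2-fluorophenyl, a number 4.7 percentage points higher from compound 1 to compound 3 (within the scatter). The change from 4-methoxyphenyl removes an oxygen and brings in a chlorine, going from one hydrogen-bond acceptor to none, and even this leaves the read-out unable to separate the compounds, so all three substituted phenyl groups now read alike at this position. Nothing on hand explains why these three groups cannot be told apart.

The compounds shown carry only a substituted phenyl on this nitrogen, so it remains open whether an amine or a carboxylic acid on that phenyl, or an acetyl group in place of the whole phenyl, would move the number beyond the scatter. They also share an unchanged core, which leaves open what a longer chain on that core would do.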